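The source may report more compounds than this note shows. Statements on the series, on what has been measured and on what is new or still open speak of the compounds shown alone.

In a toxicity assay on HepG2 cells (Homo sapiens) for inhibition, read by CellTiter-Glo, with a stated time of 48 h (a lower number here means a stronger inhibitor, a higher number a weaker inhibitor), compound 1 `Cc1cc(C)cc(NC(=O)COc2cc(C)nc3ccc(C)cc23)c1` gives 15900 nM. Compound 2 `COc1ccc2nc(C)cc(OCC(=O)Nc3cc(C)ccc3C)c2c1` reaches only a limit of the assay there, recorded as > 100000 nM. Compound 3 `COc1ccc2nc(C)cc(OCC(=O)Nc3cc(C)c(F)c(C)c3)c2c1` differs from compound 2 in a single place: 4-fluoro-3,5-dimethylphenyl in place of 2,5-dimethylphenyl on an amide-type nitrogen. Going by the values given here, because compound 2 sits at the limit (the limit of > 100000 nM in this assay, at which 1 of the 2 values shown sits), no measured step is available to set a size for this change; the step expected from compound 2 to compound 3 is an at least 1.6-fold lower number from compound 2 to compound 3 (0.22 log units; that floor lies within the scatter), toward stronger inhibition but not far. Compound 3 is therefore estimated at about 60000 nM in this assay, within a range from 15000 nM to 150000 nM, and a limit rather than a number may again be reported.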

Compound 3, half-maximal inhibitory concentration: > 100000 nM
Compound 3 gave a limit, no number; the forecaster's own chance of this, stated with the estimate: 50%; middle value at least 1.6-fold (0.22 log units) away from the limit.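

Going by these compounds alone, compound 2 and compound 3 both stop at a limit of the assay, so no step between them can be read: the limit of > 100000 nM in this assay, at which 2 of the 3 values shown sit. From the compounds shown here alone, whether 4-fluoro-3,5-dimethylphenyl in place of 2,5-dimethylphenyl changes inhibition at all in this assay stays open.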